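Triazine hydrazones at the assay limit: a pyridyl analogue

The source may hold more compounds than are shown below. What is called first, only, known or untested is meant among the compounds shown, and "the series" means these compounds.

Measured compounds in a functional assay on SW-620 cells (Homo sapiens) for inhibition, read by sulforhodamine B assay, with a stated time of 48 h; a lower number here means that less compound is tolerated, a higher number that more compound is tolerated:
Compound 1 `NS(=O)(=O)c1ccc(Nc2nc(N/N=C/c3ccc(C(F)(F)F)cc3)nc(Nc3ccccc3)n2)cc1` gives > 100000 nM, a limit of the assay rather than a number.
Compound 2 `Cc1nn(-c2ccccc2)cc1/C=N/Nc1nc(Nc2ccccc2)nc(Nc2ccc(S(N)(=O)=O)cc2)n1` gives > 100000 nM, also a limit of the assay.

Among the measured compounds shown here, compound 2 therefore stands at the limit of this assay, and no number is known for it; the only other value shown is likewise a limit. The step that the two limits leave unreadable from compound 1 to compound 2 cannot be given a size, since both ends of it are limits. This is summed up by the limit of > 100000 nM in this assay, at which 2 of the 2 values shown sit.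

Compound 3 `NS(=O)(=O)c1ccc(Nc2nc(N/N=C/c3ccccn3)nc(Nc3ccccc3)n2)cc1` differs from compound 2 by pyridin-2-yl in place of 3-methyl-1-phenyl-1H-pyrazol-4-yl on a carbon with a double bond to nitrogen. For the measured compounds named here, the only measured step that touches this position is a step that the two limits leave unreadable from compound 1 to compound 2, and its size is not readable, so no direction can be drawn from it. The two measured values nonetheless agree in sitting at the limit, and this is the basis of the expectation for compound 3. The step that the limit leaves unreadable from compound 2 to compound 3 is expected to stay within the usual scatter. Compound 3 is estimated at 150000 nM, with a range from 50000 nM to 500000 nM, and most likely this assay will again report only a limit for compound 3.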

Compound 3, concentration lethal to 50% of the cells: > 100000 nM
Compound 3 gave a limit, no number (the forecaster's own chance of this, stated with the estimate: 80%); the middle value is on the limit's open side.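

The steps among compound 1, compound 2 and compound 3 cannot be read in this assay, as each value is a limit of the assay and not a number. The compounds shown leave open how the groups on the carbon with a double bond to nitrogen compare with one another, and all three end in the same place: the limit of > 100000 nM in this assay, at which 3 of the 3 values shown sit.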